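The source may report more compounds than this note shows. Statements on the series, on what has been measured and on what is new or still open speak of the compounds shown alone.

In a functional assay on MCF7 cells (Homo sapiens) for cytotoxicity, read by MTT assay, with a stated time of 6 days (on this read-out higher numbers stand for an effect only at larger amounts of compound and lower numbers for an effect already at smaller amounts), compound 1 `COC(=O)c1c(-c2ccc([N+](=O)[O-])cc2)oc2ccccc2c1=O` gives > 25 ug/mL, which is a limit and not a number. Compound 2 `COC(=O)c1c(-c2ccc([N+](=O)[O-])cc2)oc2cc(OC)ccc2c1=O` gives > 25 ug/mL, again a limit. Compound 3 `O=C(O)c1c(-c2ccc([N+](=O)[O-])cc2)oc2ccccc2c1=O` gives > 25 ug/mL, a limit as well. The measured compounds therefore stand together at the limit of > 25 ug/mL in this assay, at which 3 of the 3 values shown sit, and compound 3 has no exact value to start from.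

Compound 4 `COc1ccc2c(=O)c(C(=O)O)c(-c3ccc([N+](=O)[O-])cc3)oc2c1` is reached from compound 3 by one change: methoxy in place of hydrogen on an aromatic carbon. The same exchange of hydrogen for methoxy has been measured once, as a step that the two limits leave unreadable from compound 1 to compound 2. The other measured change, which removes a methyl, is a step that the two limits leave unreadable from compound 1 to compound 3. Neither step has a size that can be read, so neither points in a direction. Compound 2, which carries the methoxy group, stays at its limit of > 25 ug/mL, so no shift beyond the usual scatter is expected. The expected change is a step that the limit leaves unreadable from compound 3 to compound 4. Compound 4 is estimated at 35 ug/mL, within an expected range of 18 ug/mL to 70 ug/mL, and will most likely be reported only as a limit.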

Compound 4, concentration for half-maximal effect: > 25 ug/mL
Compound 4 was reported as a limit (the forecaster's own chance of this, stated with the estimate: 85%); the middle value is on the limit's open side.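

Compound 4 also gives only a limit, so its steps from compound 3 and from compound 2 cannot be read, and all the compounds stand together: the limit of > 25 ug/mL in this assay, at which 4 of the 4 values shown sit.

The compounds shown leave open how strongly any of them acts in this assay, and whether either exchange, of hydrogen for methoxy or of methyl for hydrogen, changes that at all.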